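This account rests on a few compounds, and the source may have more. Where it says the series, first, only, none or still open, it means among the compounds named here.

Among the three compounds measured in an assay on isolated protein for inhibition of ubiquitin carboxyl-terminal hydrolase 7 (Homo sapiens), read by TR-FRET, with stated times of 75 min and 1 h (a lower number here means a stronger inhibitor, a higher number a weaker inhibitor), compound 3 `O=C(CCc1ccccc1)N1CCC(O)(CN2C=Nc3cc(NCCO)ccc3C2O)CC1` stands second highest with 16400 nM. Its nearest neighbour is compound 1 `O=C(CCc1ccccc1)N1CCC(O)(CN2C=Nc3cc(NCCN4CCCCC4)ccc3C2O)CC1`, which gives 37000 nM, the step being a 2.3-fold lower number from compound 1 to compound 3 (0.35 log units; beyond the scatter); the furthest is compound 2 `CN(C)CCNc1ccc2c(c1)N=CN(CC1(O)CCN(C(=O)CCc3ccccc3)CC1)C2O`, which gives 5980 nM, the step being a 2.7-fold higher number from compound 2 to compound 3 (0.44 log units; beyond the scatter). Compound 4 `O=C(CCc1ccccc1)N1CCC(O)(CN2C=Nc3cc(NCc4ccco4)ccc3C2O)CC1` differs from compound 3 by furan-2-yl in place of hydroxymethyl on a saturated chain carbon bound to a nitrogen on an aromatic ring. Among the measured compounds shown here, no measured step alters that position in this way; the steps from compound 1 and compound 2 to compound 3 only exchange the terminal group of the chain and were all modest, so a modest step in this assay of uncertain direction is expected. Compound 4 is therefore estimated at 16000 nM, between 4000 nM and 60000 nM, a step of a 1.0-fold lower number from compound 3 to compound 4 (0.01 log units; within the scatter).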

Compound 4, half-maximal inhibitory concentration: 9800 nM
For compound 4 the middle estimate is 1.6-fold (0.21 log units) above the measured one, and the stated range covers the measured number.
By their numbers in this assay, from the lowest: compounds 2, 4 and 3 (each within the scatter of the next, the first and the last beyond it); then compound 1.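

Among the compounds shown here, with furan-2-yl on the saturated chain carbon bound to a nitrogen on an aromatic ring, this position carries an aromatic ring for the first time, and in this assay the number stays level with the hydroxymethyl (a 1.7-fold lower number from compound 3 to compound 4 (0.22 log units; within the scatter)) and (dimethylamino)methyl (a 1.6-fold higher number from compound 2 to compound 4 (0.21 log units; within the scatter)) versions. Only the (piperidin-1-yl)methyl version stands apart (a 3.8-fold lower number from compound 1 to compound 4 (0.58 log units; beyond the scatter)). Nothing available explains these results. On these data alone, whether a phenyl ring, a furan-3-yl ring or a carboxylic acid at this position would shift the number beyond the scatter remains open.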